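Replacing an Amino Side Chain with Butyl

The source may hold more compounds than are shown below. What is called first, only, known or untested is meant among the compounds shown, and "the series" means these compounds.

In a functional assay on PC-3 cells (Homo sapiens) for antiproliferative activity, read by MTT assay, with a stated time of 72 h (a lower number here means a stronger inhibitor, a higher number a weaker inhibitor), compound 1 (`CCN(CC)CCNC(=O)c1cc(C(CC)(CC)c2ccc(C#CC(O)(CC)CC)c(C)c2)cn1CC`) gives 5350 nM and compound 2 (`CCn1cc(C(CC)(CC)c2ccc(C#CC(O)(CC)CC)c(C)c2)cc1C(=O)NCCN(C)C`) gives 10100 nM, so the two cannot be told apart. Going by the values given here, the only measured step, a 1.9-fold higher number from compound 1 to compound 2 (0.28 log units; within the scatter), puts dimethylamino in place of diethylamino and leaves the rest of the side chain intact. Compound 3 (`CCCCC(=O)c1cc(C(CC)(CC)c2ccc(C#CC(O)(CC)CC)c(C)c2)cn1CC`) goes much further, with butyl in place of (2-(dimethylamino)ethyl)amino on a carbonyl carbon. Among the compounds with values here, no measured compound shows what this larger swap does, so the small step from compound 1 to compound 2 offers only weak guidance and neither direction can be argued. The expectation in this assay therefore stays close to compound 2 at 10100 nM, with wide uncertainty. The estimated step is a 1.3-fold lower number from compound 2 to compound 3 (0.10 log units; within the scatter) as a cautious working figure. Compound 3 is expected at about 8000 nM (estimated range 2000 nM to 30000 nM).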

Compound 3, half-maximal inhibitory concentration: 48100 nM
For compound 3 the middle estimate is 6.0-fold (0.78 log units) below the measured one; the measured number lies above the stated range.
By their numbers in this assay, from the lowest: compounds 1 and 2 (each within the scatter of the next); then compound 3.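

In this assay, this carbonyl carbon proves to be a place where the group matters: butyl in place of (2-(dimethylamino)ethyl)amino gives a 4.8-fold higher number from compound 2 to compound 3 (0.68 log units; beyond the scatter), and butyl in place of (2-(diethylamino)ethyl)amino gives a 9.0-fold higher number from compound 1 to compound 3 (0.95 log units; beyond the scatter). Exchanging only the end of the side chain stayed within the scatter, whereas replacing the whole group, including both of its nitrogens, moves the number beyond it, so among these three compounds the side chain's end tolerates change better than the loss of the group does. Nothing measured here explains this rise.

The compounds shown leave open whether the amide nitrogen or the terminal amine accounts for the difference. A butylamino group on the same carbonyl carbon, which keeps the amide nitrogen but has no terminal amine, could begin to separate the two.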